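The compounds below may be only part of what the source reports. "The series", "measured", "known", "first", "only" and "open" are said of these compounds alone.

Measured in a functional assay on HT-29 cells (Homo sapiens) for cytotoxicity, read by MTT assay, with a stated time of 6 days; on this read-out lower numbers stand for an effect already at smaller amounts and higher numbers for an effect only at larger amounts of compound:
Compound 1 `COC(=O)c1c(-c2cc(OC)cc(OC)c2)oc2ccccc2c1=O`: 6.99 ug/mL
Compound 2 `COC(=O)c1c(-c2ccc(OCc3ccccc3)cc2)oc2ccccc2c1=O`: > 25 ug/mL, a limit of the assay and not a number
Compound 3 `COC(=O)c1c(-c2ccc(OCc3ccccc3)cc2)oc2ccc(OC)cc2c1=O`: 15.6 ug/mL

Of the two actual numbers, compound 3 has the higher, and its gap to compound 1 lies beyond the scatter. Compound 4 `COC(=O)c1c(-c2ccc(O)cc2)oc2ccc(OC)cc2c1=O` has not yet been measured. It differs from compound 3 by one change, benzyloxy to hydroxy: hydrogen in place of benzyl on an oxygen on an aromatic ring.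

Among the measured compounds shown here, the only measured step, an at least 1.6-fold lower number from compound 2 to compound 3 (0.20 log units; that floor lies within the scatter), is methoxy in place of hydrogen on an aromatic carbon. For the measured compounds named here, it keeps the benzyl, so it bears only loosely on this change, and no measured step removes that group. Compound 1, which carries no benzyl, gives 6.99 ug/mL, but it differs from compound 3 in more than one place and is only a weak hint.

In this assay no step beyond the scatter is therefore expected, and the estimated step is a 1.3-fold lower number from compound 3 to compound 4 (0.11 log units; within the scatter). For compound 4 the estimated value is 12 ug/mL, with an expected range from 4 ug/mL to 30 ug/mL.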

Compound 4, concentration for half-maximal effect: > 25 ug/mL
Compound 4 ended at the assay's limit; the forecaster's own chance of this, stated with the estimate: 20%; middle value at least 2.0-fold (0.31 log units) away from the limit.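

In this assay compound 4 gives > 25 ug/mL, which is a limit of the assay and not a number. The change at this oxygen on an aromatic ring is now measured directly, and hydrogen in place of benzyl gives an at least 1.6-fold higher number from compound 3 to compound 4 (0.20 log units; that floor lies within the scatter), so the read-out shows no lower number with hydroxy in place of benzyloxy, though that floor alone does not establish a real rise. The result also adds a second compound at the same ceiling, which leaves this part of the series with few actual numbers: the limit of > 25 ug/mL in this assay, at which 2 of the 4 values shown sit.

The compounds shown leave open how large this step truly is. They also leave open whether a methyl or ethyl group on this oxygen, or an amine in place of the hydroxy, would give an actual number.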